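The compounds below may be only part of what the source reports. "The series", "measured", "known", "first", "only" and "open" are said of these compounds alone.

Compound 1 `COc1cc2c(Oc3ccc(NC(=O)c4nn(-c5cccc(F)c5)c(=O)cc4C)cc3F)ccnc2cc1OCCCN1CCCC1` and compound 2 `COc1cc2c(Oc3ccc(NC(=O)c4nn(-c5cccc(F)c5)c(=O)cc4C)cc3F)ccnc2cc1OCCCN1CCN(C)CC1` share one core and differ only at the end of the side chain. In a functional assay on MKN-45 cells (Homo sapiens) for inhibition, read by MTT assay, with a stated time of 72 h (on this read-out lower numbers stand for stronger inhibition and higher numbers for weaker inhibition), compound 1 gives 120 nM, and compound 2 gives 120 nM; the step of no change at the digits printed from compound 1 to compound 2 (within the scatter) shows that exchanging the chain terminus leaves the read-out unchanged. On the numbers shown, compound 2 thus stands level with compound 1.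

Compound 3 `COc1ccc(-n2nc(C(=O)Nc3ccc(Oc4ccnc5cc(OCCCN6CCN(C)CC6)c(OC)cc45)c(F)c3)c(C)cc2=O)cc1` departs from compound 2 at a different place: 4-methoxyphenyl in place of 3-fluorophenyl on an aromatic nitrogen, that is, 4-methoxyphenyl in place of 3-fluorophenyl on the aromatic nitrogen. Within the data shown here, no measured step concerns this aromatic nitrogen; the only step in hand touches the saturated chain and was flat, so it offers no guide to the size or direction of a change at the aryl group. In this assay the expectation for compound 3 is therefore centred on what compound 2 showed, with the range widened for an untested change. Compound 3 is estimated at 150 nM, between 40 nM and 550 nM. The expected step is a 1.3-fold higher number from compound 2 to compound 3 (0.10 log units; within the scatter), which is small.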

Compound 3, half-maximal inhibitory concentration: 1230 nM
Beside the measured number, compound 3's estimate is 8.2-fold (0.91 log units) below it; measured number above the stated range.
By their numbers in this assay, from the lowest: compounds 1 and 2 (each within the scatter of the next); then compound 3.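

In this assay, the aryl group on the aromatic nitrogen proves to be a place where the read-out responds: 4-methoxyphenyl in place of 3-fluorophenyl gives a 10-fold higher number from compound 2 to compound 3 (1.01 log units; beyond the scatter), a large move towards weaker inhibition. The only earlier step, at the end of the side chain, was no change at the digits printed from compound 1 to compound 2 (within the scatter), so the flat result at the chain terminus does not carry over to this position, and this aryl group is the first place among the compounds shown where a single change moves the number beyond the scatter. Nothing at hand bears on why the number rises here.

This one change swaps the substituent and shifts its place on the phenyl ring together, so the compounds shown cannot separate the two, and 4-fluorophenyl, 3-methoxyphenyl or plain phenyl on the same nitrogen would each bear on that question. On these data alone, it also stays open whether the same change would have a step of this size with the pyrrolidin-1-yl chain end of compound 1, and how larger groups such as trifluoromethyl or ethoxy would fare on this ring.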